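Phenyl for furan on the amide of compound 3

The source may report more compounds than this note shows. Statements on the series, on what has been measured and on what is new or still open speak of the compounds shown alone.

Compound 1: `COc1ccc(S(=O)(=O)N2CCc3cccc(NCc4ccccc4)c32)cc1`; > 10000 nM
Compound 2: `COc1ccc(S(=O)(=O)N2CCc3cccc(NC(=O)c4cccs4)c32)cc1`; 43 nM
Compound 3: `COc1ccc(S(=O)(=O)N2CCc3cccc(NC(=O)c4ccco4)c32)cc1`; 9.2 nM

In a functional assay on KB cells (Homo sapiens) for cytotoxicity (a higher number here means a weaker inhibitor, a lower number a stronger inhibitor), compound 1 gives only a limit, > 10000 nM, and no number. Compound 2 gives 43 nM and compound 3 gives 9.2 nM, so compound 3 stands as the lowest of the two numbers shown, with compound 2 its nearest neighbour. The steps of an at least 230-fold lower number from compound 1 to compound 2 (2.36 log units; beyond the scatter) and an at least 1000-fold lower number from compound 1 to compound 3 (3.03 log units; beyond the scatter) show that an aryl carbonyl on the ring nitrogen in place of benzyl lowers the number by a large amount; the step of a 4.7-fold lower number from compound 2 to compound 3 (0.67 log units; beyond the scatter) shows that the choice of the aromatic ring on the carbonyl carbon itself shifts the number to a modest degree.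

Compound 4, `COc1ccc(S(=O)(=O)N2CCc3cccc(NC(=O)c4ccccc4)c32)cc1`, carries the change (phenyl in place of furan-2-yl on a carbonyl carbon). The step of a 4.7-fold lower number from compound 2 to compound 3 (0.67 log units; beyond the scatter) is the only one that bears on it, and it was modest. Compound 4 is therefore expected to keep the benefit of the aryl carbonyl. Compound 4 is expected to give a step of a 3.3-fold higher number from compound 3 to compound 4 (0.51 log units; beyond the scatter). The estimate for compound 4 in this assay is 30 nM, between 8 nM and 120 nM.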

Compound 4, half-maximal inhibitory concentration: 180 nM
Compound 4: the middle estimate sits 6.0-fold (0.78 log units) below what was measured; the measured number lies above the stated range.
By their numbers in this assay, from the lowest: compound 3; then compound 2; then compound 4. At a limit, above all of these: compound 1.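

In this assay, the ring on the carbonyl carbon matters more than the thiophen-2-yl and furan-2-yl pair alone suggested: phenyl in place of furan-2-yl is a large loss (a 20-fold higher number from compound 3 to compound 4 (1.29 log units; beyond the scatter)), and phenyl in place of thiophen-2-yl a modest one (a 4.2-fold higher number from compound 2 to compound 4 (0.62 log units; beyond the scatter)). Among these three amides, both five-membered aromatic rings with a hetero atom give lower numbers than the six-membered ring of carbon only, and none of the three goes against this. Benzoyl in place of benzyl still gives a large drop (an at least 55-fold lower number from compound 1 to compound 4 (1.74 log units; beyond the scatter)), so the carbonyl keeps much of its benefit even with phenyl, although that step rests on a limit for compound 1.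

Nothing shown accounts for this order among the rings. From the compounds shown here alone, whether a nitrogen-containing ring such as pyridin-2-yl, or a substituted furan such as 5-methylfuran-2-yl, would match furan-2-yl remains open.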